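The source may hold more compounds than are shown below. What is called first, only, known or untested is meant among the compounds shown, and "the series" means these compounds.

Compound 1 `COc1ccc(C2=C(c3cc(OC)c(OC)c(OC)c3)C(=O)C(OC(C)=O)C2)cc1` gives "not determined" (no result reported) 
Compound 2 `COc1ccc(C2=C(c3cc(OC)c(OC)c(OC)c3)C(=O)C(O)C2)cc1` gives 6.3 ug/mL 
Compound 3 `COc1ccc(C2=C(c3cc(OC)c(OC)c(OC)c3)C(=O)C(O[SiH2]C(C)(C)C)C2)cc1` gives > 100 ug/mL as a limit

In an ADME assay on HEK293 cells (Homo sapiens) for cytotoxicity, read by MTT assay, with a stated time of 72 h (on this read-out lower numbers stand for stronger inhibition and higher numbers for weaker inhibition), compound 1 has no number, so the step below has no measured starting point. The series holds one limit: the limit of > 100 ug/mL in this assay, at which 1 of the 3 values shown sits, applies to compound 3 and is not a number.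

Compound 4 `COc1ccc(C2=C(c3cc(OC)c(OC)c(OC)c3)C(=O)C(OC(C)=O)C2)cc1O` differs from compound 1 by hydroxy in place of hydrogen on an aromatic carbon in the form of hydroxy in place of hydrogen on an aromatic carbon, ortho to a methoxy group, which turns 4-methoxyphenyl into 3-hydroxy-4-methoxyphenyl.

For the measured compounds named here, the only measured step, an at least 15-fold higher number from compound 2 to compound 3 (1.20 log units; beyond the scatter), is large and beyond the scatter, but it sits on an oxygen on a saturated carbon and not at this aromatic carbon. It therefore gives no size for the present change. No step size or direction can be set in this assay without a value for compound 1. The nearest number comes from compound 2 at 6.3 ug/mL and serves as a loose anchor with a wide margin.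

For compound 4 the expected value is 6 ug/mL with an estimated range from 1 ug/mL to 40 ug/mL as the likely span.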

Compound 4, half-maximal inhibitory concentration: 92 ug/mL
Compound 4: the middle estimate sits 15-fold (1.19 log units) below what was measured; measured number outside the range, above it.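

For the compounds shown here, no step from compound 1 to compound 4 can be read in this assay: compound 1 holds no number there. The compounds shown leave open how far the change from 4-methoxyphenyl to 3-hydroxy-4-methoxyphenyl on the shared core moves the read-out in this assay.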